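The source may hold more compounds than are shown below. What is called first, only, known or untested is meant among the compounds shown, and "the series" means these compounds.

Measured compounds in a physicochemical assay for lipophilicity, read by HPLC, measured as chromatographic lipophilicity, at pH 7.4; a lower number here means a more polar compound, a higher number a more lipophilic compound:
- compound 1 `O=C(C1CCCCC1)N1CCC(C(=O)N2N=CCC2c2ccccc2)CC1` — compound 1 gives 5.4
- compound 2 `CC(C)(C)C(=O)N1N=CCC1c1cccc(Cl)c1` — compound 2 gives 6.6
- compound 3 `CC(C)(C)C(=O)N1N=CCC1c1cc(F)cc(F)c1` — compound 3 gives 6.3

Compound 3 stands second highest of the three values in this assay. Its nearest neighbour is compound 2, whose value lies slightly higher, within the scatter of the method, so no order between compound 2 and compound 3 can be claimed. The furthest value is that of compound 1, which lies lower by a step beyond the scatter; compound 1 carries a different amide substituent and differs from compound 3 in more than one place, so its gap cannot be read as a single effect.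

The next step goes from compound 3 to compound 4 `CC(C)(C)C(=O)N1N=CCC1c1cccc(F)c1`. The change is hydrogen in place of fluoro on an aromatic carbon, the rest of the molecule unchanged.

For the measured compounds named here, no single-change step between measured compounds is available in this set, so the size of this step has no direct precedent here. Removing a fluoro group in a series of this kind is expected to give a small shift towards lower values in this assay, at the edge of the scatter, as the step of a number 0.30 log units lower from compound 3 to compound 4 (within the scatter) that the estimate implies. Compound 4 is accordingly expected to give about 6 in this assay, with a range from 5.7 to 6.4.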

Compound 4, distribution coefficient: 5.9
Beside the measured number, compound 4's estimate is 0.10 log units above it; the range from low to high includes it.
By their numbers in this assay, from the lowest: compound 1; then compound 4; then compounds 3 and 2 (each within the scatter of the next).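

The series now has its first single-change steps in this assay: hydrogen in place of fluoro on an aromatic carbon (a number 0.40 log units lower from compound 3 to compound 4 (beyond the scatter)) and fluoro in place of chloro on an aromatic carbon (a number 0.70 log units lower from compound 2 to compound 4 (beyond the scatter)). Both lie beyond the scatter, so the halogen on this six-membered aromatic ring, meta to a large group, moves the read-out measurably, and compound 4 stands below both compound 2 and compound 3. Nothing at hand gives a reason for either step.

Steps involving compound 1 cannot be read, as it differs from the others in more than one place. Still open, as far as these compounds go, is how the same aromatic carbon would read with a methoxy group, a primary amine or a carboxylic acid, and whether either step carries over to the core of compound 1.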